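The source may hold more compounds than are shown below. What is called first, only, known or untested is meant among the compounds shown, and "the series" means these compounds.

Going by the values given here, in a functional assay on HCT-116 cells (Homo sapiens) for inhibition, read by MTT assay, with a stated time of 48 h (on this read-out higher numbers stand for weaker inhibition and lower numbers for stronger inhibition), compound 2 `COc1ccc(CN(C(C)=O)c2cc(OC)c(OC)c(OC)c2)cc1O` gives 270 nM, the lowest number of the three measured so far. Compound 1 `COc1ccc(CNc2cc(OC)c(OC)c(OC)c2)cc1[N+](=O)[O-]` gives 18200 nM and compound 3 `COC(=O)c1cc(CNc2cc(OC)c(OC)c(OC)c2)ccc1OC` gives 38100 nM. Both of these numbers lie well above that of compound 2, beyond the scatter.

Compound 4 `C#CC(=O)N(Cc1ccc(OC)c(O)c1)c1cc(OC)c(OC)c(OC)c1` is still unmeasured and differs from compound 2 at one place: ethynyl in place of methyl on a carbonyl carbon. In words, this is ethynyl in place of methyl on a carbonyl carbon, or acetyl to ethynylcarbonyl, where the carbonyl carbon's other neighbour is an amide-type nitrogen.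

Among the compounds with values here, only one measured step bears on this change, and only indirectly: a 2.1-fold higher number from compound 1 to compound 3 (0.32 log units; beyond the scatter). That step is modest and concerns methoxycarbonyl in place of nitro on an aromatic carbon, not the carbonyl carbon changed here. Within the data shown here, no measured pair isolates a change at this carbonyl carbon, and compound 2 is the only measured compound carrying acetyl. The data therefore give no direction, and no step beyond the scatter is expected in this assay. The estimated step is a 1.4-fold lower number from compound 2 to compound 4 (0.13 log units; within the scatter), held with low confidence. For compound 4 the estimated value is 200 nM, with an expected range from 50 nM to 800 nM.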

Compound 4, half-maximal inhibitory concentration: 310 nM
Compound 4: middle estimate off by 1.6-fold (0.19 log units), on the low side; the range from low to high includes it.
By their numbers in this assay, from the lowest: compounds 2 and 4 (each within the scatter of the next); then compound 1; then compound 3.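

In this assay, going by these compounds alone, the step at this position is a 1.1-fold higher number from compound 2 to compound 4 (0.06 log units; within the scatter), the first measured change on this carbonyl carbon whose other neighbour is the amide-type nitrogen. Methyl and ethynyl at this place cannot be told apart in this assay, so the acetyl of compound 2 is not uniquely required here, and ethynylcarbonyl, with its triple bond outside aromatic rings, is accepted without a step beyond the scatter. Nothing measured here bears on why the two groups read alike.

The compounds shown leave open how far this tolerance extends: a longer chain such as propyl, an amine or a carboxylic acid on the same carbonyl carbon could stay within the scatter of compound 2 or move beyond it, and two groups as small as methyl and ethynyl do not settle that. Also open, going by these compounds, is how a plain hydrogen in place of the acetyl would read with the rest of compound 2 kept, which would show whether any acyl group on this nitrogen matters at all.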